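Chain growth from compound 3 to compound 4

The compounds below may be only part of what the source reports. "The series", "measured", "known", "first", "only" and "open" are said of these compounds alone.

In a functional assay on WM164 cells (Homo sapiens) for antiproliferative activity, read by sulforhodamine B assay, with a stated time of 48 h (on this read-out lower numbers stand for stronger inhibition and higher numbers for weaker inhibition), compound 1 (`CCCCCCCCCCCCCCCCNC(=O)[C@@H]1CSC(c2cc(OC)c(OC)c(OC)c2)N1`) gives 700 nM and compound 2 (`CCCCCCCCCCNC(=O)[C@@H]1CSC(c2ccc(OC)c(OC)c2)N1`) gives 6100 nM while compound 3 (`CCCCCCCCCCCCCCNC(=O)[C@@H]1CSC(c2ccc(OC)c(OC)c2)N1`) gives 800 nM on the same read-out. Compound 3 thus stands level with compound 1, within the scatter, and clearly under compound 2.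

Compound 4 (`CCCCCCCCCCCCCCCCNC(=O)[C@@H]1CSC(c2ccc(OC)c(OC)c2)N1`) has not yet been measured. Its change from compound 3 is ethyl in place of hydrogen on a saturated chain carbon, ten or more bonds along the chain from an amide-type nitrogen.

Going by the values given here, one measured step bears on this directly. Butyl in place of hydrogen at that same kind of place gave a modest step beyond the scatter (a 7.6-fold lower number from compound 2 to compound 3 (0.88 log units; beyond the scatter)). The ethyl now added is the smaller of the two groups, and a single step cannot show whether the trend continues or levels off. A smaller move toward lower numbers is therefore expected in this assay and it may not clear the scatter. The expected move is a 1.8-fold lower number from compound 3 to compound 4 (0.25 log units; within the scatter) on this estimate. Compound 4 is expected at 450 nM with an estimated range from 180 nM to 1100 nM for the coming measurement.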

Compound 4, half-maximal inhibitory concentration: 500 nM
Compound 4: middle estimate off by 1.1-fold (0.05 log units), on the low side; the range from low to high includes it.
By their numbers in this assay, from the lowest: compounds 4, 1 and 3 (each within the scatter of the next); then compound 2.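

Working notes: in this assay, ethyl in place of hydrogen on a saturated chain carbon, ten or more bonds along the chain from an amide-type nitrogen, gives a 1.6-fold lower number from compound 3 to compound 4 (0.20 log units; within the scatter), so this further extension does not separate from the scatter, while the earlier butyl step, a 7.6-fold lower number from compound 2 to compound 3 (0.88 log units; beyond the scatter), does; over the whole span, hexyl in place of hydrogen gives a 12-fold lower number from compound 2 to compound 4 (1.09 log units; beyond the scatter), the largest step among the chain changes shown. The series also gains its first comparison on an aromatic carbon: hydrogen in place of methoxy gives a 1.4-fold lower number from compound 1 to compound 4 (0.15 log units; within the scatter), so with the chain unchanged, the removal of that methoxy does not separate from the scatter in this pair. No independent data on these compounds bear on why either change reads as it does.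

As far as these compounds go, a longer chain than that of compound 4 remains open, so these compounds cannot show whether the numbers stay level or move again beyond this length. Also open, from the compounds shown here alone, are an amine or a carboxylic acid on that saturated chain carbon, and fluorine in place of methoxy on the aromatic carbon.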